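A few compounds are considered here, and "the series" means these few. Any claim that something is new, unique, unknown or untested is made for them only; others in the source may bear on it.

Working notes on the series. Compound 1 `O=C1c2ccccc2N(COCc2ccccc2)S(=O)(=O)N1Cc1ccccc1` carries (benzyloxy)methyl on a sulfonamide nitrogen in a ring and benzyl on a saturated chain carbon bound to an amide-type nitrogen in a ring. In a functional assay on HEL cells (Homo sapiens) for cytotoxicity (on this read-out higher numbers stand for lower toxicity in this test and lower numbers for higher toxicity in this test), compound 1 gives only a limit of the assay, > 50 ug/mL. Compound 2 `O=C1c2ccccc2NS(=O)(=O)N1Cc1ccccc1` has hydrogen in place of (benzyloxy)methyl on that sulfonamide nitrogen; in this assay compound 2 gives 50 ug/mL, so that a number no higher from compound 1 to compound 2 (the limit leaves the size open). Compound 3 `CC(=O)OCCOCN1C(=O)c2ccccc2NS1(=O)=O` has 2-acetoxyethoxy in place of phenyl on the saturated chain carbon bound to the amide-type nitrogen. In this assay compound 3 gives only a limit of the assay, > 50 ug/mL. Thus a number no lower from compound 2 to compound 3 (the limit leaves the size open). Compound 3 stands at the limit of > 50 ug/mL in this assay, at which 2 of the 3 values shown sit, the ceiling of the numbers shown; compound 2 alone gives a plain number, and it sits within the scatter of that ceiling.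

Compound 4 `O=C1c2ccccc2NS(=O)(=O)N1COCc1ccccc1` is not yet measured. Against compound 3 the change is phenyl in place of acetoxymethyl on a saturated chain carbon bound to an oxygen on a saturated carbon. Both measured steps bear on it, since they shift the same two side groups, and neither shows a size readable beyond the limit. No step beyond the scatter is therefore expected, and a step that the limit leaves unreadable from compound 3 to compound 4 is the estimated step. Compound 4 is expected to give 60 ug/mL in this assay, between 25 ug/mL and 120 ug/mL, most likely reported again only as a limit.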

Compound 4, minimum cytotoxic concentration: > 50 ug/mL
Compound 4 was reported as a limit (the forecaster's own chance of this, stated with the estimate: 70%); the middle value is on the limit's open side.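

Compound 3 and compound 4 each give only a limit of the assay in this assay, so no step can be read between them: the limit of > 50 ug/mL in this assay, at which 3 of the 4 values shown sit.

The compounds shown leave open how far the true numbers of compound 1, compound 3 and compound 4 lie past that limit, and whether their side groups set them apart at all.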